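Removing the chlorine from a chalcone-linked pyridinone

The compounds below may be only part of what the source reports. "The series", "measured", "known", "first", "only" and "open" are said of these compounds alone.

Measured compounds:
Compound 1, `COc1cc(/C=C/C(=O)c2cccc(-n3cc(-c4ccc(Cl)cc4)[nH]c3=O)c2)ccc1O`: in a functional assay on ACHN cells (Homo sapiens) for inhibition (on this read-out higher numbers stand for weaker inhibition of growth and lower numbers for stronger inhibition of growth), compound 1 gives 2190 nM.
Compound 2, `COc1cc(/C=C/C(=O)c2cccc(-n3cc(-c4ccccc4)[nH]c3=O)c2)cc(OC)c1OC`: in this assay compound 2 gives 1600 nM.

Compound 1 has the highest of the two numbers, but its nearest neighbour is compound 2, whose number is lower by an amount that lies within the usual scatter of this assay, so the two compounds cannot be told apart on these data. Going by the values given here, compound 2 also differs from compound 1 in more than one place, so no single step between measured compounds is available to guide what follows.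

The step to compound 3, `COc1cc(/C=C/C(=O)c2cccc(-n3cc(-c4ccccc4)[nH]c3=O)c2)ccc1O`, changes compound 1 in one place: hydrogen in place of chloro on an aromatic carbon. Seen one bond further out, this reads as 4-chlorophenyl to phenyl.

Among the compounds with values here, with no measured step of this kind at hand, the expectation is that compound 3 stays close to compound 1, with at most a small move toward weaker inhibition of growth, and the step of a 1.2-fold higher number from compound 1 to compound 3 (0.07 log units; within the scatter) is expected to sit within the scatter. Compound 3 is estimated at 2600 nM, with a range from 1100 nM to 6000 nM.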

Compound 3, concentration for 50% growth inhibition: 2500 nM
Compound 3: the middle estimate sits 1.0-fold (0.02 log units) above what was measured, and the stated range covers the measured number.
By their numbers in this assay, from the lowest: compounds 2, 1 and 3 (each within the scatter of the next).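

Going by these compounds alone, replacing the chloro of the 4-chlorophenyl group with hydrogen gives, in this assay, a 1.1-fold higher number from compound 1 to compound 3 (0.06 log units; within the scatter) and is the first change here that can be read on its own, since these two compounds differ in one place only. On this read-out, the chlorine and the hydrogen at this position cannot be told apart, so in this one pair the chloro group is not required for the growth inhibition seen with compound 1. No measurement shown here bears on why the two compounds read alike.

This single pair does not show whether other groups on the same aromatic carbon, such as an amine, a carboxylic acid or a propyl chain, would also stay within the scatter or would shift the number clearly in either direction. It also leaves open whether the change from chloro to hydrogen would read the same way if other parts of the core of compound 1 were different.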